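The source may report more compounds than this note shows. Statements on the series, on what has been measured and on what is new or still open speak of the compounds shown alone.

In a functional assay on M14 cells (Homo sapiens) for inhibition, read by sulforhodamine B assay, with a stated time of 48 h (a lower number here means a stronger inhibitor of growth, a higher number a weaker inhibitor of growth), compound 1, `COc1ccc(NC(=O)Nc2n[nH]c3ccccc23)cc1`, gives only a limit of the assay, > 100000 nM. Compound 2, `CCCCOc1ccc(NC(=O)n2nc(N)c3ccccc32)cc1`, gives 18600 nM, and compound 3, `Nc1nn(C(=O)Nc2c(F)cccc2F)c2ccccc12`, gives 74700 nM. Of the two numbers, compound 2 holds the lower one, and its gap to compound 3 lies beyond the scatter. Compound 4, `Nc1nn(C(=O)Nc2ccc(Cc3ccccc3)cc2)c2ccccc12`, is not yet measured. It differs from compound 2 in a single place: benzyl in place of butoxy on an aromatic carbon. For the measured compounds named here, no measured pair shows a change of this kind, so the direction is open; in this assay a shift no larger than the scatter is expected, with a slight lean toward a lower number. Compound 4 is therefore estimated at 14000 nM, between 5000 nM and 45000 nM. The expected step is a 1.3-fold lower number from compound 2 to compound 4 (0.12 log units; within the scatter).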

Compound 4, concentration for 50% growth inhibition: 772 nM
Estimate against measurement, compound 4: 18-fold (1.26 log units) above; the whole stated range lies above it.
By their numbers in this assay, from the lowest: compound 4; then compound 2; then compound 3. At a limit, above all of these: compound 1.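

In this assay, for the compounds shown here, the aromatic carbon para to a large group proves far more sensitive than the earlier compounds could show, since they offered no pair differing in one place: benzyl in place of butoxy gives a 24-fold lower number from compound 2 to compound 4 (1.38 log units; beyond the scatter). The change places a six-membered aromatic ring of carbon only at this position and removes the oxygen of the butoxy chain. Nothing measured here explains the step.

From the compounds shown here alone, whether the ring or the carbon linking it matters more stays open; a phenyl or phenoxy group at this position would separate the two. A longer alkoxy chain would show whether butoxy itself limits compound 2.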